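The source may report more compounds than this note shows. Statements on the series, on what has been measured and on what is new or still open speak of the compounds shown alone.

Compound 1, `COc1ccc(Cc2cc(-c3ccc(Cl)cc3)nn(CC(=O)Nc3ccc(Br)cc3)c2=O)cc1`, in an assay on HL-60 cells for agonist activity at N-formyl peptide receptor 3 (Homo sapiens), read by calcium flux; on this read-out lower numbers stand for an effect already at smaller amounts and higher numbers for an effect only at larger amounts of compound: > 50000 nM, a limit of the assay.
Compound 2, `COc1ccc(Cc2cc(-c3ccc(F)cc3)nn(CC(=O)Nc3ccc(Br)cc3)c2=O)cc1`, in this assay: > 50000 nM, a limit of the assay.
Compound 3, `Cc1cc(Cc2cccc(F)c2)c(=O)n(CC(=O)Nc2ccc(Br)cc2)n1`, in this assay: > 50000 nM, a limit of the assay.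

Compound 1 and compound 2 share one core and differ by chloro in place of fluoro on an aromatic carbon; the resulting step that the two limits leave unreadable from compound 2 to compound 1, which stays unreadable because of the limit of > 50000 nM in this assay, at which 3 of the 3 values shown sit. Compound 3 carries a different core, and the difference between the core of compound 3 and that of compound 2 is not broken down here. Compound 4, `Cc1cc(Cc2cccc(Cl)c2)c(=O)n(CC(=O)Nc2ccc(Br)cc2)n1`, is not yet measured; from compound 3 it differs by chloro in place of fluoro on an aromatic carbon. This is the same kind of change as that from compound 2 to compound 1, though the place differs: there the group sits para to a large group, here meta to a large group. The step is expected to be a number no higher from compound 3 to compound 4 (the limit leaves the size open), an expectation resting on (the limit of > 50000 nM in this assay, at which 3 of the 3 values shown sit). In this assay compound 4 is estimated at 50000 nM, between 20000 nM and 200000 nM, most likely reported again only as a limit.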

Compound 4, half-maximal effective concentration: > 50000 nM
Compound 4: only a limit was reported (the forecaster's own chance of this, stated with the estimate: 85%); the middle value lies on the limit itself.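

In this assay compound 4 gives > 50000 nM, a limit of the assay. Going by these compounds alone, no step from compound 3 to compound 4 can be read: the limit of > 50000 nM in this assay, at which 4 of the 4 values shown sit.
The compounds shown leave open whether chloro in place of fluoro changes anything in this assay.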